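The source may hold more compounds than are shown below. What is called first, only, known or untested is meant among the compounds shown, and "the series" means these compounds.

Measured so far in a toxicity assay on HepG2 2.2.15 cells (Homo sapiens) for cytotoxicity, read by CellTiter-Glo; on this read-out lower numbers stand for higher toxicity in this test and higher numbers for lower toxicity in this test:
- compound 1 `CC1(C)CC(=O)N(c2cnn3c2CN(C(=O)Nc2cc(F)c(F)c(F)c2)C(C2CC2)C3)C1`: 115000 nM
- compound 2 `O=C1CC(c2ncco2)CN1c1cnn2c1CN(C(=O)Nc1cc(F)c(F)c(F)c1)C(C1CC1)C2`: a limit of the test only, > 200000 nM

Compound 2 therefore has no numbered value in this assay; it sits at the limit (the limit of > 200000 nM in this assay, at which 1 of the 2 values shown sits). Within the data shown here, the single measured step, an at least 1.7-fold higher number from compound 1 to compound 2 (0.24 log units; that floor lies within the scatter), is the only comparison available, and its floor lies within the scatter, so the two measured compounds cannot be ordered on cytotoxicity.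

Compound 3 `O=C1CC(c2nccs2)CN1c1cnn2c1CN(C(=O)Nc1cc(F)c(F)c(F)c1)C(C1CC1)C2` differs from compound 2 by 1,3-thiazol-2-yl in place of 1,3-oxazol-2-yl on a saturated ring carbon. Among the measured compounds shown here, the only step that bears on it is the one from compound 1 to compound 2, which exchanged the whole 4,4-dimethyl-2-oxopyrrolidin-1-yl group and still gave no step beyond the scatter; the present exchange of 1,3-oxazol-2-yl for 1,3-thiazol-2-yl on a saturated ring carbon is expected to give none either, a number no higher from compound 2 to compound 3 (the limit leaves the size open). Compound 3 is thus estimated at 200000 nM, between 100000 nM and 400000 nM, and most probably again reported only as a limit in this assay.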

Compound 3, half-maximal cytotoxic concentration: 115000 nM
Beside the measured number, compound 3's estimate is 1.7-fold (0.24 log units) above it, and the stated range covers the measured number.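

In this assay, the saturated ring carbon two ring bonds from the ring nitrogen now carries a group for which compound 3 gives a numbered value, which the 1,3-oxazol-2-yl group of compound 2 did not give. The exchange of 1,3-oxazol-2-yl for 1,3-thiazol-2-yl gives an at least 1.7-fold lower number from compound 2 to compound 3 (0.24 log units; that floor lies within the scatter), and its true size stays open because compound 2 is only a limit: the limit of > 200000 nM in this assay, at which 1 of the 3 values shown sits.

The exchange of the whole group gives no change at the digits printed from compound 1 to compound 3 (within the scatter), so 2-oxo-4-(1,3-thiazol-2-yl)pyrrolidin-1-yl and 4,4-dimethyl-2-oxopyrrolidin-1-yl cannot be told apart on this read-out.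

Open, as far as these compounds go, is whether a phenyl ring, an aminomethyl group or a carboxylic acid on the same saturated ring carbon would give a step beyond the scatter in this assay. Also open, from the compounds shown here alone, is how compound 2 and compound 3 order on cytotoxicity.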